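The source may report more compounds than this note shows. Statements on the series, on what has been measured and on what is new or still open speak of the compounds shown alone.

Of the compounds shown here, three that share one core have been measured in a functional assay on A-375 cells (Homo sapiens) for antiproliferative activity, read by CCK-8 assay, with a stated time of 72 h; on this read-out higher numbers stand for weaker inhibition and lower numbers for stronger inhibition. Compound 1 `Cc1ccc(Nc2nc(Cl)nc3c2ncn3Cc2ccc(C(=O)Nc3ccccc3N)cc2)cc1`, which carries 4-methylphenyl on the nitrogen, gives 470 nM. Compound 2 `Nc1ccccc1NC(=O)c1ccc(Cn2cnc3c(Nc4ccccc4)nc(Cl)nc32)cc1`, with phenyl at that place, gives 2800 nM. Compound 3 `Nc1ccccc1NC(=O)c1ccc(Cn2cnc3c(NCc4ccccc4)nc(Cl)nc32)cc1`, with benzyl there, gives 5830 nM, the highest number of the three and so the weakest inhibition in this small set.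

Compound 4 `Nc1ccccc1NC(=O)c1ccc(Cn2cnc3c(Nc4ccc(-c5ccccn5)cc4)nc(Cl)nc32)cc1` has not been measured yet. It differs from compound 3 at that same nitrogen, with 4-(pyridin-2-yl)phenyl in place of benzyl (4-(pyridin-2-yl)phenyl in place of benzyl on a nitrogen on an aromatic ring).

Within the data shown here, three measured steps bear on this change. The swap of phenyl for benzyl is seen as a 2.1-fold higher number from compound 2 to compound 3 (0.32 log units; beyond the scatter), a modest step, and the swap of 4-methylphenyl for benzyl as a 12-fold higher number from compound 1 to compound 3 (1.09 log units; beyond the scatter), a large one. Losing the methyl is seen as a 6.0-fold higher number from compound 1 to compound 2 (0.78 log units; beyond the scatter), so in this pair the substituted phenyl gives the lower number. Both benzyl steps therefore run against benzyl, and a modest to large drop in this assay is expected on leaving it. Among the measured compounds shown here, no measured compound carries a pyridin-2-yl group, so the size of that drop is uncertain.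

The expected change is a 6.5-fold lower number from compound 3 to compound 4 (0.81 log units; beyond the scatter). For compound 4 the estimated value is 900 nM, within an expected range from 220 nM to 3600 nM.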

Compound 4, half-maximal inhibitory concentration: 18500 nM
Estimate against measurement, compound 4: 21-fold (1.31 log units) below; measured number above the stated range.
By their numbers in this assay, from the lowest: compound 1; then compound 2; then compound 3; then compound 4.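

Pyridin-2-yl on the aromatic carbon gives a 6.6-fold higher number from compound 2 to compound 4 (0.82 log units; beyond the scatter) when it replaces hydrogen and a 39-fold higher number from compound 1 to compound 4 (1.60 log units; beyond the scatter) when it replaces methyl in this assay, so a group at this carbon can move the number in either direction: methyl lowers it, while pyridin-2-yl raises it. Among these compounds, the new 4-(pyridin-2-yl)phenyl group also does worse than benzyl, the poorest group among the earlier compounds, with a 3.2-fold higher number from compound 3 to compound 4 (0.50 log units; beyond the scatter) on this read-out, which makes compound 4 the weakest inhibitor of the four and shows that a substituent on the phenyl ring does not by itself lower the number. Nothing measured here gives a reason for this reversal.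

The compounds shown leave open whether the rise goes with the ring nitrogen of the pyridine or simply with the larger group, a question that a plain phenyl ring at the same carbon could help to settle. They also leave open how a smaller group there, such as methoxy or an amine, would compare with methyl.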